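A few compounds are considered here, and "the series" means these few. Any claim that something is new, unique, unknown or untested is made for them only; others in the source may bear on it.

In a functional assay on the whole organism for inhibition, with Scenedesmus acutus as the target (a lower number here means a stronger inhibitor, a higher number a weaker inhibitor), compound 1 `Cc1cc(Cl)ccc1/N=c1\sc(=S)n2n1CCCC2` gives 457 nM, while compound 2 `CC(C)Oc1cc(-n2c(=S)n3n(c2=S)CCCC3)c(F)cc1Cl` gives 7.59 nM, the lower of the two numbers and lower by more than the scatter. Compound 3 `Fc1cc(Cl)ccc1-n1c(=S)n2n(c1=S)CCCC2` has hydrogen in place of isopropoxy on an aromatic carbon of compound 2 (hydrogen in place of isopropoxy on an aromatic carbon). Among the measured compounds shown here, no measured pair shows this change alone, so the expectation rests on the structures only: a rise in the number in this assay, beyond the scatter. The expected size is a 20-fold higher number from compound 2 to compound 3 (1.30 log units; beyond the scatter). For compound 3, the estimated value is 150 nM, with an expected range of 30 nM to 750 nM.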

Compound 3, half-maximal inhibitory concentration: 23.4 nM
Beside the measured number, compound 3's estimate is 6.4-fold (0.81 log units) above it; measured number below the stated range.
By their numbers in this assay, from the lowest: compound 2; then compound 3; then compound 1.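

In this assay, replacing isopropoxy with hydrogen on the aromatic carbon ortho to the chloro group and para to the fluoro group gives a 3.1-fold higher number from compound 2 to compound 3 (0.49 log units; beyond the scatter) as a modest change. Isopropoxy at this position therefore goes with stronger inhibition, yet it is not required for a low number, since compound 3 still gives 23.4 nM without it. No measurement at hand explains why the number moves at this position. On these data alone, whether a methoxy group, an amine or a longer chain on this carbon would match isopropoxy remains open.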